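The source may report more compounds than this note shows. Statements on the series, on what has been measured and on what is new or still open speak of the compounds shown alone.

Of the compounds shown here, three built on a shared core have been measured in a functional assay, with a stated time of 20 min, tested at 2 uM; on this read-out higher numbers stand for a stronger effect at the one concentration tested and lower numbers for a weaker effect. Compound 1, `COc1cc(/C=C/C(=O)C2=C(/C=C/c3ccc(O)c(OC)c3)NC(=O)NC2c2ccccc2O)ccc1O`, gives in this assay a value of 33.6%. Compound 2, `COc1cc(/C=C/C(=O)C2=C(/C=C/c3ccc(O)c(OC)c3)NC(=O)NC2c2ccc(N(C)C)cc2)ccc1O`, differs from compound 1 by a single change, (4-(dimethylamino)phenyl in place of 2-hydroxyphenyl on a saturated ring carbon), and in this assay compound 2 gives 17.9%. Among the compounds with values here, the resulting step, a number 15.7 percentage points lower from compound 1 to compound 2 (beyond the scatter), is the one measured example of this change. Compound 3, `COc1cc(/C=C/C(=O)C2=C(/C=C/c3ccc(O)c(OC)c3)NC(=S)NC2c2ccccc2O)ccc1O`, has a core that differs from the core of compound 1; the difference between the two cores is not broken down here. In this assay compound 3 gives 25%, which lies within the usual scatter of the values of both compound 1 and compound 2, so those three numbers alone allow no ranking of compound 3 against either.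

Compound 4, `COc1cc(/C=C/C(=O)C2=C(/C=C/c3ccc(O)c(OC)c3)NC(=S)NC2c2ccc(N(C)C)cc2)ccc1O`, is not yet measured. It stands to compound 3 as compound 2 stands to compound 1: the change is 4-(dimethylamino)phenyl in place of 2-hydroxyphenyl on a saturated ring carbon, at a place described in the same words in both cases, so it is the same change on a different core. Within the data shown here, the expectation for compound 4 rests on the single prior example, the step of a number 15.7 percentage points lower from compound 1 to compound 2 (beyond the scatter), carried over to compound 3, and is estimated as a number 15 percentage points lower from compound 3 to compound 4 (beyond the scatter). Among the measured compounds shown here, compound 4 is therefore expected to give about 10% in this assay, within an estimated range from 0% to 22%, kept wide since only one example of the change exists.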

Compound 4, a percentage reported as activity, at one concentration (the size of the read-out at that concentration, not a potency): 30.2%
Compound 4: the middle estimate sits 20.2 percentage points below what was measured, and the stated range ends below it.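

On the core of compound 3, placing 4-(dimethylamino)phenyl where 2-hydroxyphenyl stood on the saturated ring carbon gives a number 5.2 percentage points higher from compound 3 to compound 4 (within the scatter) in this assay, so on this core the change has no readable effect on the read-out. Set beside the earlier step, this shows that the change did not carry over from the core of compound 1 to the core of compound 3 with the same outcome: the same change on two cores in this assay, a number 15.7 percentage points lower (beyond the scatter) from compound 1 to compound 2 and a number 5.2 percentage points higher (within the scatter) from compound 3 to compound 4, 20.9 percentage points apart, beyond the scatter of two such steps What this does not show is why the two cores part ways, or how the change would behave on any further core, as each core offers only a single pair of compounds, measured at one concentration, and a single pair cannot separate a lasting trend from a one-off result.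

The compounds shown leave open whether the gap between the cores follows the 2-hydroxyphenyl group, the 4-(dimethylamino)phenyl group or both. How a plain phenyl, a 4-hydroxyphenyl or a carboxylic acid on the same saturated ring carbon would read on each of the two cores also remains an open question.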